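The source may report more compounds than this note shows. Statements on the series, on what has been measured and on what is new or still open speak of the compounds shown alone.

Measured so far in a functional assay on MDA-MB-231 cells (Homo sapiens) for antiproliferative activity, read by MTT assay, with a stated time of 48 h; a lower number here means a stronger inhibitor, a higher number a weaker inhibitor
- compound 1 (`CCN1C(=O)C(O)(Cc2nnn[nH]2)c2ccccc21`) gives > 100000 nM (a limit)
- compound 2 (`O=C1N(Cc2ccc(Br)cc2)c2ccc(F)cc2C1(O)Cc1nnn[nH]1`) gives > 100000 nM (a limit)

Compound 2 has no number in this assay and stands at a limit, with > 100000 nM as its only result. Among the compounds with values here, the series so far offers no more than the limit of > 100000 nM in this assay, at which 2 of the 2 values shown sit (a limit, not a graded response).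

Compound 3 (`O=C1N(Cc2ccc(Br)cc2)c2ccc(Br)cc2C1(O)Cc1nnn[nH]1`) differs from compound 2 by bromo in place of fluoro on an aromatic carbon. Within the data shown here, no measured step covers this change. With compound 2 at > 100000 nM (a limit), no step beyond the scatter is expected in this assay in either direction. The expected size is a number no higher from compound 2 to compound 3 (the limit leaves the size open) (an estimate). For compound 3 the estimated value is 100000 nM (expected range 30000 nM to 300000 nM), and a further limit is the likeliest result.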

Compound 3, half-maximal inhibitory concentration: 65400 nM
Beside the measured number, compound 3's estimate is 1.5-fold (0.18 log units) above it; measured number inside the range.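

In this assay, within the data shown here, compound 3 gives 65400 nM, the only value that is a number and not a limit. The change to bromo in place of fluoro on an aromatic carbon reads as an at least 1.5-fold lower number from compound 2 to compound 3 (0.18 log units; that floor lies within the scatter), so this position can carry a compound to a measurable value, while the true size of the step stays unknown and no real gain is shown. The series thus has a single measured point, with the remaining results still at a limit: the limit of > 100000 nM in this assay, at which 2 of the 3 values shown sit.

From the compounds shown here alone, whether chloro, methoxy or an amine on this same aromatic carbon would also give a number in this assay remains open. Also open, going by these compounds, is whether bromo at this position would give a number on the core of compound 1, which carries an ethyl group.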